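Moving the fluorine on the indole of compound 2

The compounds below may be only part of what the source reports. "The series", "measured", "known", "first", "only" and "open" are said of these compounds alone.

Measured so far in an assay on RPMI-8226 cells for antagonist activity at P2X purinoceptor 7 (Homo sapiens), read by calcium flux; a lower number here means a stronger inhibitor, a higher number a weaker inhibitor:
compound 1, `O=c1[nH]c2ccccc2n1CCCCCN1CCN(C(c2ccccc2)c2ccccc2)CC1`, 560 nM
compound 2, `Fc1cccc2c1ccn2CCCCN1CCN(C(c2ccccc2)c2ccccc2)CC1`, 150 nM

Among these two numbers, compound 2 stands lowest; its nearest neighbour is compound 1, and the step of a 3.7-fold lower number from compound 1 to compound 2 (0.57 log units; beyond the scatter) goes beyond the scatter. That step, however, exchanges the whole bicyclic group on the chain and does not speak to a change of fluorine position within one indole.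

Compound 3, `Fc1ccc2c(ccn2CCCCN2CCN(C(c3ccccc3)c3ccccc3)CC2)c1`, differs from compound 2 only by 5-fluoro-1H-indol-1-yl in place of 4-fluoro-1H-indol-1-yl on a saturated chain carbon, four bonds along the chain from an amine nitrogen in a ring; the two hold the same atoms, joined differently. Among the measured compounds shown here, no measured step bears on this change, so there is no ground to expect a shift beyond the scatter in this assay in either direction. Compound 3 is therefore estimated at 150 nM, within a range of 60 nM to 400 nM, which means an expected step of no change at the digits printed from compound 2 to compound 3 (within the scatter).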

Compound 3, half-maximal inhibitory concentration: 120 nM
For compound 3 the middle estimate is 1.3-fold (0.10 log units) above the measured one; low and high end bracket the measured number.
By their numbers in this assay, from the lowest: compounds 3 and 2 (each within the scatter of the next); then compound 1.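

In this assay, putting 5-fluoro-1H-indol-1-yl in place of 4-fluoro-1H-indol-1-yl gives a 1.3-fold lower number from compound 2 to compound 3 (0.10 log units; within the scatter) and so shows that, between these two compounds, the fluorine's position on the indole has no effect that can be told from the scatter. Among the compounds shown here, the step from the group of compound 1 remains beyond the scatter with the other fluorine position, at a 4.7-fold lower number from compound 1 to compound 3 (0.67 log units; beyond the scatter), so it is not tied to the single fluoroindole of compound 2. No measurement at hand offers an explanation for this result.

Still open, on these data alone, is whether plain 1H-indol-1-yl, or a chlorine, methoxy or nitrile group in place of the fluorine, would stay within the scatter of these values. Also open, as far as these compounds go, is how a longer chain would act with these fluoroindoles.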